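The source may hold more compounds than are shown below. What is called first, only, known or untested is meant among the compounds shown, and "the series" means these compounds.

Measured so far in a functional assay on HeLa cells (Homo sapiens) for cytotoxicity, read by MTT assay, with a stated time of 24 h; a lower number here means a stronger inhibitor, a higher number a weaker inhibitor:
Compound 1 `C=CC1=C(C(=O)Nc2ccccc2OC)C(c2ccc(F)cc2)OC1`: a limit of the assay, > 100000 nM.
Compound 2 `C=CC1=C(C(=O)NCc2ccc(C)cc2)C(c2ccc(OC)cc2)OC1`: 15900 nM.

Within the data shown here, compound 2 holds the only numerical value shown; the other result is a limit (the limit of > 100000 nM in this assay, at which 1 of the 2 values shown sits). Compound 3 `C=CC1=C(C(=O)Nc2ccccc2OC)C(c2ccc(OC)cc2)OC1` differs from compound 2 by 2-methoxyphenyl in place of 4-methylbenzyl on an amide-type nitrogen, so that compound 3 carries the same amide substituent as compound 1. Among the measured compounds shown here, no step between measured compounds is given, so the size of the change is open. The expected change in this assay is a 3.1-fold higher number from compound 2 to compound 3 (0.50 log units; beyond the scatter), toward weaker inhibition. Compound 3 is estimated to give 50000 nM, between 15000 nM and 150000 nM.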

Compound 3, half-maximal inhibitory concentration: > 100000 nM
Compound 3: only a limit was reported; the forecaster's own chance of this, stated with the estimate: 40%; middle value at least 2.0-fold (0.30 log units) away from the limit.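

In this assay, 2-methoxyphenyl in place of 4-methylbenzyl on the amide-type nitrogen gives an at least 6.2-fold higher number from compound 2 to compound 3 (0.79 log units; beyond the scatter), the first readable step, showing that the amide substituent matters with the rest of the structure held constant. Compound 3 gives > 100000 nM, which is a limit of the assay. The step from compound 1 to compound 3 cannot be read, so methoxy and fluoro on the aromatic carbon cannot be ranked with this amide substituent: the limit of > 100000 nM in this assay, at which 2 of the 3 values shown sit.

As far as these compounds go, it remains open whether a plain benzyl, a phenethyl chain or an unsubstituted phenyl on the nitrogen would retain a measurable value. From the compounds shown here alone, how fluoro behaves alongside 4-methylbenzyl also remains open.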